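A few compounds are considered here, and "the series" means these few. Any claim that something is new, unique, unknown or untested is made for them only; others in the source may bear on it.

Series notes. Compound 1 `Cc1nc(C)n(-c2nc(-c3ccccc3)cc(=O)[nH]2)n1`, compound 2 `CNC(=O)c1ccc(-c2cc(=O)[nH]c(-n3nc(C)cc3C)n2)cc1` and compound 3 `CCc1cc(C)nn1-c1nc(C(F)(F)F)cc(=O)[nH]1` have been run in an ADME assay on CHO cells (Cricetulus griseus) for cytotoxicity, read by MTT assay; a higher number here means a weaker inhibitor, a lower number a stronger inhibitor; compound 4 `Cc1cc(Nc2ccccn2)n(-c2nc(C(F)(F)F)cc(=O)[nH]2)n1` has not. Compound 1 returns only a limit in this assay, > 50000 nM. Compound 2 likewise returns only a limit, > 50000 nM. For the measured compounds named here, compound 3 is the one member with a number, giving 108000 nM, so it is the sole point in the set that can anchor a comparison; the other two sit at the limit of > 50000 nM in this assay, at which 2 of the 3 values shown sit, and no ordering between any pair is possible. Going by the values given here, with no two measured compounds differing in a single place, no measured step exists in this set.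

Compound 4 differs from compound 3 in one place: (pyridin-2-yl)amino in place of ethyl on an aromatic carbon. The ethyl leaves and the (pyridin-2-yl)amino group enters on an aromatic carbon of the five-membered aromatic ring with 2 nitrogen, next to the ring nitrogen. Among the compounds with values here, no measured step in this assay shows what such an exchange does; all three measured results lie in the region of weak inhibition. The expected step is a 1.4-fold lower number from compound 3 to compound 4 (0.13 log units; within the scatter), that is, none beyond the scatter. For compound 4 the estimated value in this assay is 80000 nM, with a range from 30000 nM to 200000 nM, and a fair chance that only a limit is returned.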

Compound 4, half-maximal inhibitory concentration: 23000 nM
Beside the measured number, compound 4's estimate is 3.5-fold (0.54 log units) above it, outside the stated range (below it).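

In this assay, for the compounds shown here, this position gives the first readable step: a 4.7-fold lower number from compound 3 to compound 4 (0.67 log units; beyond the scatter), with (pyridin-2-yl)amino in place of ethyl on an aromatic carbon of the five-membered aromatic ring with 2 nitrogen, next to the ring nitrogen. The number therefore responds to the group at this carbon by more than the scatter, and the change runs towards stronger inhibition in these cells, even though the entering group is much the larger of the two. This single pair changes size, ring content and hydrogen-bond donor count together, so it cannot show which of these goes with the lower number.

Going by these compounds alone, compound 1 and compound 2 each return only a limit and belong to no single-place pair, so no step involving them can be read: the limit of > 50000 nM in this assay, at which 2 of the 4 values shown sit. Whether a plain amino group or a phenylamino group on the same carbon would give a similar step remains open, as does whether the step would carry over to a core bearing a phenyl ring in place of the trifluoromethyl group.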